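This account rests on a few compounds, and the source may have more. Where it says the series, first, only, none or still open, it means among the compounds named here.

Measured so far:
compound 1, `Cc1nc(C#Cc2ccc(C(=O)N[C@H](C)C(C)(C)O)nc2)cs1`: 66.6%
compound 2, `CC(C)CNC(=O)c1ccc(C#Cc2cccc(F)c2)cn1`: 58.2%

Both compounds were tested in a functional assay on HEK293 cells for positive allosteric modulation of metabotropic glutamate receptor 5 (Rattus norvegicus), read by fluorescence and calcium flux; a higher number here means a larger maximal response, a lower number a smaller maximal response. Compound 1 reaches 66.6% and compound 2 reaches 58.2%; the gap between these two numbers lies within the usual scatter of repeated measurements, so on these two numbers compound 2 cannot be set apart from compound 1. Compound 3, `CC1(CNC(=O)c2ccc(C#Cc3cccc(F)c3)cn2)COC1`, has not yet been measured in this assay. It differs from compound 2 in one place: 3-methyloxetan-3-yl in place of isopropyl on a saturated chain carbon bound to an amide-type nitrogen. Among the compounds with values here, no pair of measured compounds differing in a single place is available, so the data give no guide to how large a step in this assay such a change brings. In the absence of any such guide, the expected step from compound 2 to compound 3 is a number 1.8 percentage points higher from compound 2 to compound 3 (within the scatter), that is, none beyond the scatter. Compound 3 is therefore estimated to give 60% in this assay, with a range from 42% to 78%.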

Compound 3, largest response reached (reported as efficacy), in percent of the reference or control that the assay uses: 60.4%
Compound 3: the middle estimate sits 0.4 percentage points below what was measured; low and high end bracket the measured number.
By their numbers in this assay, from the lowest: compounds 2, 3 and 1 (each within the scatter of the next).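

Putting 3-methyloxetan-3-yl in place of isopropyl on a saturated chain carbon bound to an amide-type nitrogen brings, in this assay, a number 2.2 percentage points higher from compound 2 to compound 3 (within the scatter). Within the data shown here, this is the first single-place comparison at this position, and it shows that a larger group with a four-membered non-aromatic ring and a hydrogen-bond acceptor leaves the maximal response within the scatter of the isopropyl compound. No measurement shown here accounts for the size of this step.

From the compounds shown here alone, one step at one position does not show how far this insensitivity extends, so it remains open whether an amine, a carboxylic acid or a longer chain at this place would move the response beyond the scatter. Going by these compounds, it is also open whether the same change would give a similar step on the core of compound 1.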